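Furan to Propyl on the Exocyclic Double Bond

The source may report more compounds than this note shows. Statements on the series, on what has been measured and on what is new or still open speak of the compounds shown alone.

The measured compounds:
Compound 1, `CC(=O)OC[C@H]1O[C@@H](n2cc(CN3C(=O)/C(=C\c4ccc(N(C)C)cc4)c4ccccc43)nn2)[C@H](OC(C)=O)[C@@H](OC(C)=O)[C@@H]1OC(C)=O`, gives 25000 nM in a functional assay on HeLa cells (Homo sapiens) for cytotoxicity, read by sulforhodamine B assay, with a stated time of 48 h; on this read-out lower numbers stand for stronger inhibition and higher numbers for weaker inhibition.
Compound 2, `CC(=O)OC[C@H]1O[C@@H](n2cc(CN3C(=O)/C(=C\c4cccs4)c4ccccc43)nn2)[C@H](OC(C)=O)[C@@H](OC(C)=O)[C@@H]1OC(C)=O`, gives > 100000 nM in this assay, which is a limit of the assay and not a number.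
Compound 3, `CC(=O)OC[C@H]1O[C@@H](n2cc(CN3C(=O)/C(=C\c4ccco4)c4ccccc43)nn2)[C@H](OC(C)=O)[C@@H](OC(C)=O)[C@@H]1OC(C)=O`, gives > 100000 nM in this assay, again a limit of the assay and not a number.

Compound 3 therefore stands at the limit of > 100000 nM in this assay, at which 2 of the 3 values shown sit, with no readable number of its own. The step to compound 4, `CCC/C=C1\C(=O)N(Cc2cn([C@@H]3O[C@H](COC(C)=O)[C@@H](OC(C)=O)[C@H](OC(C)=O)[C@H]3OC(C)=O)nn2)c2ccccc21`, is propyl in place of furan-2-yl on a double-bonded chain carbon bound to a double-bonded ring carbon. Within the data shown here, two measured steps bear on this region of the shared core: an at least 4.0-fold higher number from compound 1 to compound 2 (0.60 log units; beyond the scatter) and an at least 4.0-fold higher number from compound 1 to compound 3 (0.60 log units; beyond the scatter), both leading from the 4-(dimethylamino)phenyl group of compound 1 to a five-membered aromatic ring and both ending at the limit. Between compound 2 and compound 3 there is a step that the two limits leave unreadable from compound 2 to compound 3. Among the measured compounds shown here, compound 4 removes the aromatic ring altogether in favour of a short chain, and no measured compound shows a return to a readable number once the 4-(dimethylamino)phenyl group is gone. The step that the limit leaves unreadable from compound 3 to compound 4 is therefore expected to leave compound 4 at the limit as well. The expected value for compound 4 is 150000 nM, within 40000 nM to 500000 nM.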

Compound 4, half-maximal inhibitory concentration: 46300 nM
Compound 4: the middle estimate sits 3.2-fold (0.51 log units) above what was measured, and the stated range covers the measured number.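

In this assay, the position on a double-bonded chain carbon bound to a double-bonded ring carbon turns out not to need an aromatic ring for a readable number: propyl gives an at least 2.1-fold lower number from compound 3 to compound 4 (0.33 log units; beyond the scatter), and in place of thiophen-2-yl it gives an at least 2.1-fold lower number from compound 2 to compound 4 (0.33 log units; beyond the scatter). Propyl also holds up against the 4-(dimethylamino)phenyl group, with a 1.9-fold higher number from compound 1 to compound 4 (0.27 log units; within the scatter). Only compound 2 and compound 3 remain at a limit of the assay, which is not a number: the limit of > 100000 nM in this assay, at which 2 of the 4 values shown sit.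

The full size of the steps to compound 4 cannot be read from these limits, nor can the step between compound 2 and compound 3. As far as these compounds go, it stays open whether a longer chain, a branched isopropyl group or an unsubstituted phenyl ring at this position would give a lower number than compound 1 and compound 4 do.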